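The compounds below may be only part of what the source reports. "The series", "measured", "known", "first", "only" and "open" are said of these compounds alone.

Compound 1 `Nc1ccccc1NC(=O)c1ccc(CSC(=S)N2CCN(C3CCCCC3)CC2)cc1` was tested in a functional assay on MGC-803 cells (Homo sapiens) for antiproliferative activity, read by CCK-8 assay, with a stated time of 72 h, tested at 2 uM (on this read-out higher numbers stand for a stronger effect at the one concentration tested and lower numbers for a weaker effect), where compound 1 gives 16.9%. For the measured compounds named here, the only other measured compound, compound 2 `Nc1ccccc1NC(=O)c1ccc(CSC(=S)N2CCc3cc([N+](=O)[O-])ccc32)cc1`, gives 26.8% in this assay. Compound 1 stands at the low end of these two numbers, but the gap to compound 2 is within the scatter, so no order between them can be claimed. Compound 3 `Nc1ccccc1NC(=O)c1ccc(CSC(=S)N2CCN(c3ccc(F)cc3)CC2)cc1` has not yet been measured in this assay. It differs from compound 1 in one place: 4-fluorophenyl in place of cyclohexyl on an amine nitrogen in a ring. Going by the values given here, no step between measured compounds shows how this change acts in this assay, and compound 1 and compound 2 differ at several places, so that pair gives no guidance. Compound 3 is therefore expected to stay close to compound 1, with the step of a number 3.1 percentage points higher from compound 1 to compound 3 (within the scatter) expected to be no larger than the scatter. Compound 3 is estimated at 20%, within the range 5% to 40%.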

Compound 3, a percentage reported as inhibition, at one concentration (the size of the read-out at that concentration, not a potency): 18.8%
Estimate against measurement, compound 3: 1.2 percentage points above; low and high end bracket the measured number.
By their numbers in this assay, from the lowest: compounds 1, 3 and 2 (each within the scatter of the next).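

In this assay, for the compounds shown here, the first one-place step at this amine nitrogen in a ring is a number 1.9 percentage points higher from compound 1 to compound 3 (within the scatter), with 4-fluorophenyl in place of cyclohexyl. This step lies within the scatter, so the read-out does not separate the aromatic six-membered carbon ring bearing fluorine from the non-aromatic six-membered carbon ring at this position. Nothing measured here bears on why the two groups are not told apart.

The compounds shown leave open whether a group of another kind on this nitrogen, such as a carboxylic acid, a basic amine or a longer chain ending in a hydroxyl group, would give a step beyond the scatter. They also leave open how 4-fluorophenyl would compare with unsubstituted phenyl at this position.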